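From Fluoro to Chloro on an Aromatic Carbon

This account rests on a few compounds, and the source may have more. Where it says the series, first, only, none or still open, it means among the compounds named here.

Compound 1 `O=C(Nc1ccc(F)cc1Cl)c1cc(Cl)ccc1O` has a single measured neighbour, compound 2 `O=C(Nc1ccc(F)cc1)c1cc(Cl)ccc1O`. In a physicochemical assay for solubility (a lower number here means a less soluble compound, a higher number a more soluble compound), compound 1 gives 1.2 ug/mL and compound 2 gives 1.6 ug/mL, so the two stand level, within the scatter of repeated measurements. The unmeasured compound 3 `O=C(Nc1ccc(Cl)cc1Cl)c1cc(Cl)ccc1O` differs from compound 1 in one place: chloro in place of fluoro on an aromatic carbon. Chloro takes the place of fluoro on an aromatic carbon, meta to a chloro group and para to a large group.

Going by the values given here, only one measured step bears on this change: a 1.3-fold higher number from compound 1 to compound 2 (0.12 log units; within the scatter). Among the compounds with values here, there, hydrogen replaces chloro at a different place, and no measured step involves fluoro, so this is only a loose guide. It does show the number in this assay staying within the scatter when one halogen position changes. On that thin evidence, no step beyond the scatter is expected, in either direction. The estimated step is a 1.2-fold lower number from compound 1 to compound 3 (0.08 log units; within the scatter). Compound 3 is expected at 1 ug/mL, with an estimated range from 0.45 ug/mL to 2.2 ug/mL.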

Compound 3, solubility: < 1 ug/mL
Compound 3 ended at the assay's limit; the forecaster's own chance of this, stated with the estimate: 10%; the middle value lies on the limit itself.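

In this assay compound 3 gives < 1 ug/mL, and this value is a limit of the assay, not a number. Swapping fluoro for chloro at this position, para to a large group, gives an at least 1.2-fold lower number from compound 1 to compound 3 (0.07 log units; that floor lies within the scatter); that size is only a floor, and the true step may be larger, but the size of any larger step cannot be read from these data. This is the first look at this position, as compound 1 and compound 2 both carry fluoro there, and it shows that chloro at this place puts the compound at the edge of what this assay can report, so the comparison gives a bound and no exact size: the limit of < 1 ug/mL in this assay, at which 1 of the 3 values shown sits.

The compounds shown hold only fluoro and chloro at this position, so it remains open how this assay would respond to a quite different group there, such as an amine or a carboxylic acid. On these data alone, it is also open whether such a group would give a step beyond the scatter, and whether it would lift the number clear of the limit.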